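The compounds below may be only part of what the source reports. "The series", "measured", "known", "first", "only" and "open" are said of these compounds alone.

Measured so far in a functional assay on CHO cells for antagonist activity at prostaglandin E2 receptor EP1 subtype (Homo sapiens), read by FLIPR and calcium flux; a lower number here means a stronger inhibitor, a higher number a weaker inhibitor:
- compound 1, `Cc1ccc(S(=O)(=O)N(Cc2nnc(Cc3ccc(N(C)C)cc3)o2)c2cccc(Cl)c2C)cc1`: 20 nM
- compound 2, `Cc1ccc(S(=O)(=O)N(Cc2nnc(Cc3cccc(Cl)c3)o2)c2cccc(Cl)c2C)cc1`: 2000 nM

Compound 2 stands at the higher of the two numbers, and so is the weaker inhibitor of the pair. For the measured compounds named here, the only difference from compound 1 lies on the saturated chain carbon bound to an aromatic carbon, and that single change gave a 100-fold higher number from compound 1 to compound 2 (2.00 log units; beyond the scatter).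

Compound 3, `COc1ccc(NCc2nnc(CN(c3cccc(Cl)c3C)S(=O)(=O)c3ccc(C)cc3)o2)cc1`, alters compound 2 at the same place: (4-methoxyphenyl)amino in place of 3-chlorophenyl on a saturated chain carbon bound to an aromatic carbon. Going by the values given here, the one measured step that bears on this is the exchange at that position between compound 1 and compound 2, which was large and went toward weaker inhibition when the aminophenyl group was removed. Compound 3 brings a nitrogen and an oxygen back into that position, though arranged differently from compound 1, so the step is expected to go the other way, toward a lower number, but not necessarily all the way back. The expected step is a 6.7-fold lower number from compound 2 to compound 3 (0.82 log units; beyond the scatter). Compound 3 is therefore estimated at 300 nM in this assay, within a range from 50 nM to 2000 nM.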

Compound 3, inhibition constant: 79.4 nM
Estimate against measurement, compound 3: 3.8-fold (0.58 log units) above; the range from low to high includes it.
By their numbers in this assay, from the lowest: compound 1; then compound 3; then compound 2.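

In this assay, the result shows that the weak value of compound 2 is not the ceiling for this position on a saturated chain carbon bound to an aromatic carbon: replacing 3-chlorophenyl with (4-methoxyphenyl)amino gave a 25-fold lower number from compound 2 to compound 3 (1.40 log units; beyond the scatter) and so recovered much of the ground separating the first two compounds. A second group, with a different make-up from 4-(dimethylamino)phenyl, therefore also gives a far lower number than 3-chlorophenyl, yet the two are not equal, since the exchange between them gave a 4.0-fold higher number from compound 1 to compound 3 (0.60 log units; beyond the scatter) and leaves compound 1 as the stronger inhibitor. Nothing measured here explains why these groups differ as they do.

The exchange in compound 3 alters two things at once, as it adds the amine nitrogen in the link and also carries a methoxy group on the ring, so its effect cannot be divided between them. A plain phenylamino group, without the methoxy, and a 4-methoxyphenyl group bound directly to the same carbon, without the amine nitrogen, would separate those two parts.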